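A few compounds are considered here, and "the series" means these few. Any claim that something is new, unique, unknown or untested is made for them only; others in the source may bear on it.

For the measured compounds named here, in an ADME assay on TZM cells (Homo sapiens) for cytotoxicity, read by XTT assay, with a stated time of 4 days (a lower number here means that less compound is tolerated, a higher number that more compound is tolerated), compound 2 `Cc1cc(N)cc(C)c1Oc1cc(Nc2ccc(C#N)cc2)c(N)cc1C(F)(F)F` gives 15800 nM, the only actual number so far. Compound 1 `CNC(=O)c1cc2ncn(-c3ccc(C#N)cc3)c2cc1Oc1c(C)cc(/C=C/C#N)cc1C`, which also bears 2-cyanoethenyl, is reported only as a limit, > 890000 nM. Compound 3 `Cc1cc(/C=C/C#N)cc(C)c1Oc1cc(Nc2ccc(C#N)cc2)c(N)cc1C(F)(F)F` differs from compound 2 in one place: 2-cyanoethenyl in place of amino on an aromatic carbon, meta to two methyl groups. Going by the values given here, no measured step covers this change, so the size is uncertain. Resting on that limit of compound 1, a modest rise in this assay is expected, an estimated 1.9-fold higher number from compound 2 to compound 3 (0.28 log units; within the scatter). For compound 3 the estimated value is 30000 nM, with an expected range from 8000 nM to 150000 nM.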

Compound 3, half-maximal cytotoxic concentration: 15000 nM
Compound 3: middle estimate off by 2.0-fold (0.30 log units), on the high side, and the stated range covers the measured number.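

In this assay, 2-cyanoethenyl in place of amino on this aromatic carbon, meta to two methyl groups, gives a 1.1-fold lower number from compound 2 to compound 3 (0.02 log units; within the scatter), so here the loss of the amino group's hydrogen-bond donor and the gain of three heavy atoms leave compound 2 and compound 3 within the scatter of each other. The 2-cyanoethenyl group alone therefore does not bring compound 3 to the kind of reading of compound 1, which differs in more than one place and is known only as a limit: the limit of > 890000 nM in this assay, at which 1 of the 3 values shown sits.

On these data alone, it remains open whether a carboxylic acid or a longer chain at this position would read the same. As far as these compounds go, it is also open which of the other differences in compound 1 goes with its limit.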